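The compounds below may be only part of what the source reports. "The series", "measured", "known", "first", "only" and "open" are said of these compounds alone.

Measured compounds in a functional assay on HT-29 cells (Homo sapiens) for antiproliferative activity, read by MTT assay, with a stated time of 72 h; on this read-out higher numbers stand for weaker inhibition and lower numbers for stronger inhibition:

Compound 1 `CN(C)CCn1cnnc1-c1cc(Oc2ccc(NC(=O)Nc3ccc(F)c(F)c3)cc2F)ccn1` gives 3620 nM.
Compound 2 `CN(C)CCn1cnnc1-c1cc(Oc2ccc(NC(=O)Nc3ccc(F)c(Cl)c3)cc2F)ccn1` gives 720 nM.
Compound 3 `CN(C)CCn1cnnc1-c1cc(Oc2ccc(NC(=O)Nc3ccc(Cl)cc3Cl)cc2F)ccn1` gives 1890 nM.

Among these three numbers compound 3 stands second highest. Its nearest neighbour is compound 1, and the gap between them, a 1.9-fold lower number from compound 1 to compound 3 (0.28 log units; within the scatter), lies within the scatter, so the two cannot be told apart. Its furthest neighbour is compound 2, from which it is separated by a 2.6-fold higher number from compound 2 to compound 3 (0.42 log units; beyond the scatter), a gap beyond the scatter.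

Compound 4 `CCN(CC)CCn1cnnc1-c1cc(Oc2ccc(NC(=O)Nc3ccc(Cl)cc3Cl)cc2F)ccn1` is not yet measured. It differs from compound 3 in one place: diethylamino in place of dimethylamino on a saturated chain carbon, two bonds along the chain from an aromatic nitrogen. The chain itself and everything else in the molecule stay as they are.

Going by the values given here, none of the measured steps bears on this change. The steps of a 5.0-fold lower number from compound 1 to compound 2 (0.70 log units; beyond the scatter), a 1.9-fold lower number from compound 1 to compound 3 (0.28 log units; within the scatter) and a 2.6-fold higher number from compound 2 to compound 3 (0.42 log units; beyond the scatter) all alter the substituents on a different part of the molecule, and the amine at the end of the chain is the same in compounds 1, 2 and 3. There is therefore no measured guide to how lengthening the amine substituents affects this assay.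

With no evidence for a change in either direction, compound 4 is expected to give a number close to that of compound 3, that is a step of a 1.0-fold higher number from compound 3 to compound 4 (0.00 log units; within the scatter), within the scatter. The estimate for compound 4 is 1900 nM, with a range from 800 nM to 4500 nM.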

Compound 4, half-maximal inhibitory concentration: 3590 nM
Estimate against measurement, compound 4: 1.9-fold (0.28 log units) below; low and high end bracket the measured number.
By their numbers in this assay, from the lowest: compound 2; then compounds 3, 4 and 1 (each within the scatter of the next).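

Replacing dimethylamino with diethylamino at the end of the chain takes the group from 3 to 5 heavy atoms, and in this assay this gives a 1.9-fold higher number from compound 3 to compound 4 (0.28 log units; within the scatter), so compound 3 and compound 4 cannot be told apart. Going by these compounds alone, this is the first measured look at this part of the molecule, since every earlier step changed only the aryl group on the amide-type nitrogen. With the 2,4-dichlorophenyl group in place, the larger diethylamino group is therefore tolerated in this read-out, and the amine end shows no clear sensitivity to this particular swap, although one pair cannot set a general rule; nothing at hand offers an explanation for this result.

Going by these compounds, whether the same swap would also leave the number unmoved with the 3-chloro-4-fluorophenyl group of compound 2 remains open. Also open, on these data alone, is what a larger dipropylamino group, a smaller methylamino group or a longer chain carrying the amine would do in this assay.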